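Replacing a Methoxyphenyl Arm: Expected Growth Inhibition

The source may report more compounds than this note shows. Statements on the series, on what has been measured and on what is new or still open speak of the compounds shown alone.

Of the compounds shown here, two sharing a five-membered aromatic core have been measured in a functional assay on OVCAR cells (Homo sapiens) for inhibition, read by MTT assay, with a stated time of 48 h; on this read-out lower numbers stand for stronger inhibition of growth and higher numbers for weaker inhibition of growth. Compound 1 `COc1ccc(-c2cc(-c3ccc([N+](=O)[O-])cc3)[nH]n2)cc1OC` gives 28900 nM in this assay. Compound 2 `COc1ccccc1-c1cc(-c2ccccc2-c2ccccc2)n[nH]1` gives 14200 nM in this assay, the lower of the two numbers, and the gap between compound 2 and compound 1 lies beyond the usual scatter of repeated measurements. Compound 3 `Oc1ccc(-c2cc(-c3ccccc3-c3ccccc3)n[nH]2)cc1` has not yet been measured. It differs from compound 2 in one place: 4-hydroxyphenyl in place of 2-methoxyphenyl on an aromatic carbon. Among the measured compounds shown here, no step between two measured compounds shows what such an exchange does in this assay, so the expectation rests on compound 2 alone. Without such a precedent, the step from compound 2 to compound 3 is expected to be modest and could run either way, estimated as a 1.4-fold lower number from compound 2 to compound 3 (0.15 log units; within the scatter). Compound 3 is accordingly expected to give about 10000 nM in this assay, with a likely range from 3000 nM to 35000 nM.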

Compound 3, concentration for 50% growth inhibition: 6200 nM
Beside the measured number, compound 3's estimate is 1.6-fold (0.21 log units) above it; low and high end bracket the measured number.
By their numbers in this assay, from the lowest: compound 3; then compound 2; then compound 1.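

In this assay, exchanging 2-methoxyphenyl for 4-hydroxyphenyl on this aromatic carbon gives a 2.3-fold lower number from compound 2 to compound 3 (0.36 log units; beyond the scatter), the only step shown that can be read at this position. The position therefore responds to what it carries, and this swap of one aryl arm for another moves the number towards stronger inhibition of growth rather than losing it. Two things change together, since the oxygen sits at a different place on the ring and the entering group carries a hydrogen-bond donor that the leaving group lacks, and no measurement shown says why the number fell.

Going by these compounds, it stays open whether the hydroxyl group itself matters, or its place on the ring, or simply the loss of the methoxy group. Also open, on these data alone, is how an amine or a carboxylic acid would fare on the same ring in place of the hydroxyl group.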